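This account rests on a few compounds, and the source may have more. Where it says the series, first, only, none or still open, it means among the compounds named here.

Within the data shown here, in a functional assay on HCT-116 cells (Homo sapiens) for inhibition, read by colorimetric assay, with a stated time of 3 days (on this read-out lower numbers stand for stronger inhibition and higher numbers for weaker inhibition), two compounds that share one core have numbers so far. Compound 1 (`O=C(CCCCCCNC(=O)C(O)(O)C(F)(F)F)Nc1ccc(F)cc1F`) gives 18500 nM, and compound 2 (`O=C(CCCCCCNC(=O)C(O)(O)C(F)(F)F)Nc1ccc(Cl)cc1`) gives 4230 nM, the lower of the two. Among the measured compounds shown here, the only measured step is a 4.4-fold lower number from compound 1 to compound 2 (0.64 log units; beyond the scatter), a change of the group on an amide-type nitrogen.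

Compound 3 (`O=C(CCCCCCNC(=O)C(O)(O)C(F)(F)F)Nc1nc2ccccc2s1`) changes that same group again: 1,3-benzothiazol-2-yl in place of 4-chlorophenyl on an amide-type nitrogen. In words, 1,3-benzothiazol-2-yl stands in place of 4-chlorophenyl on an amide-type nitrogen.

For the measured compounds named here, the single measured step bears on this only loosely. It shows that a swap at this place can shift the number by a modest amount, but neither measured compound carries 1,3-benzothiazol-2-yl, so the data give no direction. On these data alone, the expectation in this assay is therefore no clear step beyond the scatter, while a move of similar modest size either way stays open. The expected outcome is a 1.2-fold higher number from compound 2 to compound 3 (0.07 log units; within the scatter). For compound 3 the estimated value is 5000 nM, with an expected range from 1500 nM to 17000 nM.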

Compound 3, half-maximal inhibitory concentration: 2370 nM
The estimate for compound 3 lay 2.1-fold (0.32 log units) above the measured number; the measured number falls inside the stated range.
By their numbers in this assay, from the lowest: compounds 3 and 2 (each within the scatter of the next); then compound 1.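

In this assay, among these compounds, the amide-type nitrogen now carries a group with a five-membered aromatic ring holding hetero atoms, where the earlier compounds had only a six-membered aromatic ring of carbon. The step to it is a 1.8-fold lower number from compound 2 to compound 3 (0.25 log units; within the scatter) and so 1,3-benzothiazol-2-yl and 4-chlorophenyl cannot be told apart on this read-out, even though the entering group adds hydrogen-bond acceptors that 4-chlorophenyl lacks. Set against 2,4-difluorophenyl, the same group gives a 7.8-fold lower number from compound 1 to compound 3 (0.89 log units; beyond the scatter) and compound 1 thus stands apart from both other compounds, while nothing available explains these numbers.

The compounds shown leave open how a plain phenyl, a pyridin-2-yl or a benzothiazol-2-yl bearing an amine or a carboxylic acid would behave on this nitrogen, and so whether the gap to compound 1 belongs to the fluorines or to something else in that group. They also leave open how much the rest of the shared core contributes, since a shorter or longer chain would test a part that stays the same in all three compounds.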